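Hydroxymethyl for Ethoxycarbonyl on Two Cyclopropane Amides

The compounds below may be only part of what the source reports. "The series", "measured", "known", "first", "only" and "open" are said of these compounds alone.

Measured compounds:
Compound 1, `CCOC(=O)[C@@]1(C(=O)Nc2ccccc2Cl)C[C@H]1c1cc(OC)c(OC)c(OC)c1`: 14400 nM
Compound 2, `CCOC(=O)[C@@]1(C(=O)NCc2ccc(C)cc2)C[C@@H]1c1cc(OC)c(OC)c(OC)c1`: > 100000 nM
Compound 3, `COc1cc([C@@H]2C[C@@]2(CO)C(=O)Nc2ccccc2Cl)cc(OC)c1OC`: 13300 nM

Of the compounds shown here, three have been tested in a functional assay on HeLa cells (Homo sapiens) for cytotoxicity, read by MTT assay, with a stated time of 48 h; on this read-out lower numbers stand for stronger inhibition and higher numbers for weaker inhibition. Compound 1 has the structure `CCOC(=O)[C@@]1(C(=O)Nc2ccccc2Cl)C[C@H]1c1cc(OC)c(OC)c(OC)c1` and gives 14400 nM in this assay. Compound 3, `COc1cc([C@@H]2C[C@@]2(CO)C(=O)Nc2ccccc2Cl)cc(OC)c1OC`, gives 13300 nM in this assay. The two differ in one place, (hydroxymethyl in place of ethoxycarbonyl on a saturated ring carbon), and the step of a 1.1-fold lower number from compound 1 to compound 3 (0.03 log units; within the scatter) is small. Compound 2 has the structure `CCOC(=O)[C@@]1(C(=O)NCc2ccc(C)cc2)C[C@@H]1c1cc(OC)c(OC)c(OC)c1`; in this assay compound 2 gives only a limit, > 100000 nM, which is the limit of the measurement and not a number. The difference between the core of compound 2 and the core of compound 1 is not broken down here.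

The compound still to be measured, compound 4, has the structure `COc1cc([C@H]2C[C@@]2(CO)C(=O)NCc2ccc(C)cc2)cc(OC)c1OC`. It differs from compound 2 by hydroxymethyl in place of ethoxycarbonyl on a saturated ring carbon, the same change that was made from compound 1 to compound 3, with the same surroundings in both cases. Since the step of a 1.1-fold lower number from compound 1 to compound 3 (0.03 log units; within the scatter) from compound 1 to compound 3 stayed within the scatter, compound 4 is expected to stand close to compound 2, and the expected step is a number no higher from compound 2 to compound 4 (the limit leaves the size open). Because compound 2 sits at the limit (the limit of > 100000 nM in this assay, at which 1 of the 3 values shown sits), compound 4 is also expected to be reported mostly as a limit rather than as a number. The estimate for compound 4 in this assay is 100000 nM, between 40000 nM and 300000 nM.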

Compound 4, half-maximal inhibitory concentration: > 100000 nM
Compound 4: a limit, no number (the forecaster's own chance of this, stated with the estimate: 75%); the middle value lies on the limit itself.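

For the compounds shown here, compound 4, like compound 2, is reported in this assay only as a limit and not as a number, so no step between compound 2 and compound 4 can be read: the limit of > 100000 nM in this assay, at which 2 of the 4 values shown sit. The compounds shown leave open whether hydroxymethyl in place of ethoxycarbonyl shifts the value at all on the core of compound 2, where both compounds lie at the limit.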